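Vinyl for Methoxyethyl on an Amidine Chain

This account rests on a few compounds, and the source may have more. Where it says the series, first, only, none or still open, it means among the compounds named here.

Measured compounds:
Compound 1 `COCC(=N)NCCCCN` — 21%
Compound 2 `COCCCC(=N)NCCCCN` — 14%

Two amidines have been measured in an assay for inhibition of arginase-1 (Bos taurus), with a stated time of 30 min, tested at 1 mM; a lower number here means less inhibition, a higher number more inhibition at the concentration tested (going by the name of the read-out). Compound 1 gives 21%, and compound 2 gives 14%. Compound 2 has the lower of the two numbers, yet the step of a number 7 percentage points lower from compound 1 to compound 2 (within the scatter) lies within the scatter, so the two compounds cannot be ordered on these data.

Compound 3 `C=CCC(=N)NCCCCN` differs from compound 2 by vinyl in place of 2-methoxyethyl on a saturated chain carbon bound to a carbon with a double bond to nitrogen. For the measured compounds named here, the one measured step that touches the same saturated chain carbon was a number 7 percentage points lower from compound 1 to compound 2 (within the scatter), a small one. Going by the values given here, no measured step removes the oxygen of the chain, so the effect of that loss is unknown here. On this slender basis compound 3 is expected to give about 16%, with a range from 3% to 35%. The estimated step of a number 2 percentage points higher from compound 2 to compound 3 (within the scatter) is expected to stay within the scatter.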

Compound 3, a percentage reported as inhibition, at one concentration (the size of the read-out at that concentration, not a potency): 6%
Compound 3: the middle estimate sits 10 percentage points above what was measured; the measured number falls inside the stated range.
By their numbers in this assay, from the lowest: compounds 3, 2 and 1 (each within the scatter of the next, the first and the last beyond it).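

At this saturated chain carbon, the change to vinyl from 2-methoxyethyl gives a number 8 percentage points lower from compound 2 to compound 3 (within the scatter) in this assay, so this single change cannot be told apart from repeat scatter. For the compounds shown here, the change to vinyl from methoxy, however, gives a number 15 percentage points lower from compound 1 to compound 3 (beyond the scatter), the first step at this place to clear the scatter, which shows that the group carried here can shift the read-out, if only modestly, while compound 2 stays within the scatter of both neighbours. No measurement is available that bears on the reason for this result.

No pair shown differs by the chain oxygen alone or by the double bond alone, so the separate contribution of each remains unresolved. Also open, as far as these compounds go, is how an ethyl group, a primary amine or a carboxylic acid at this carbon would read out in this assay.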